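A few compounds are considered here, and "the series" means these few. Any claim that something is new, unique, unknown or untested is made for them only; others in the source may bear on it.

Measured so far in a functional assay on MCF7 cells (Homo sapiens) for cytotoxicity, read by MTT assay; a higher number here means a weaker inhibitor, a lower number a stronger inhibitor
compound 1 `CC(=O)O[C@@H]1OC(=O)[C@@](C)(C(C)=O)[C@@H]1C` gives > 10000 nM as a limit
compound 2 `CC(=O)O[C@@H]1OC(=O)[C@@](O)(C(C)=O)[C@@H]1C` gives > 50000 nM as a limit
compound 3 `CC(=O)[C@]1(C)C(=O)O[C@@H](OC(=O)c2ccccc2)[C@H]1C` gives 8000 nM as a number

Compound 1 stands on the limit of > 10000 nM in this assay, at which 1 of the 3 values shown sits, and has no number of its own. Compound 2 likewise stands on the limit of > 50000 nM in this assay, at which 1 of the 3 values shown sits, and has no number either.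

Compound 4 `CCO[C@@H]1OC(=O)[C@@](C)(C(C)=O)[C@@H]1C` differs from compound 1 in one place, as counted in ethyl in place of acetyl on an oxygen on a saturated carbon and in words ethyl in place of acetyl on an oxygen on a saturated carbon, or acetoxy to ethoxy.

Going by the values given here, two measured steps bear on this only weakly. The step that the two limits leave unreadable from compound 1 to compound 2 lies on a saturated ring carbon, not at the oxygen in question. The step of an at least 1.2-fold lower number from compound 1 to compound 3 (0.09 log units; that floor lies within the scatter) alters the acetyl itself, with phenyl in place of methyl on a carbonyl carbon, and its floor stays within the scatter. The expectation rests on compound 3, which at 8000 nM is the only true number in the series, and no measured change at this group is shown beyond the scatter.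

The expected step that the limit leaves unreadable from compound 1 to compound 4 is small and, if it shows at all, is expected to run toward a higher number. For compound 4 the estimate is 20000 nM with an expected range of 8000 nM to 60000 nM and a fair chance of only a limit.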

Compound 4, half-maximal inhibitory concentration: > 50000 nM
Compound 4: no number, only a limit; the forecaster's own chance of this, stated with the estimate: 55%; middle value at least 2.5-fold (0.39 log units) away from the limit.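

Compound 1 and compound 4 each carry only a limit in this assay, and the step between them, acetoxy to ethoxy, cannot be read. The compounds shown leave open whether ethyl in place of acetyl on this oxygen changes the read-out at all, and what number either compound would give.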